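The compounds below may be only part of what the source reports. "The series", "measured", "known", "first", "only" and "open" are said of these compounds alone.

Measured compounds:
Compound 1, `Nc1nc(Cl)c(-c2nc3ccc(Cl)cc3s2)c(N[C@@H]2C[C@H](CO)[C@@H](O)[C@H]2O)n1`, gives 16000 nM in an ADME assay on cells (Homo sapiens) for cytotoxicity, read by polymerase chain reaction, with a stated time of 3 days; on this read-out higher numbers stand for lower toxicity in this test and lower numbers for higher toxicity in this test.
Compound 2, `Cc1nc(NC(C)C)nc(N[C@@H]2C[C@H](CO)[C@@H](O)[C@H]2O)c1-c1nc2ccccc2s1`, gives 13000 nM in this assay.

The numbers for compound 2 and compound 1 lie within the usual scatter of repeated measurements of each other, so neither can be set apart from the other on these two values; compound 2 simply sits in the same range that both measured compounds occupy. Among the measured compounds shown here, no pair of measured compounds differing at a single site is available, so there is no measured step to lean on.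

Compound 3, `Cc1nc(N(C)C)nc(N[C@@H]2C[C@H](CO)[C@@H](O)[C@H]2O)c1-c1nc2ccccc2s1`, has not yet been measured in this assay. Compared with compound 2 it differs in one place: dimethylamino in place of isopropylamino on an aromatic carbon.

For the measured compounds named here, with no measured step of this kind to draw on, and with both measured compounds giving numbers within the scatter of each other, the expected step of no change at the digits printed from compound 2 to compound 3 (within the scatter) is none beyond the usual scatter. Compound 3 is therefore expected to give 13000 nM, with a range from 5000 nM to 35000 nM.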

Compound 3, half-maximal cytotoxic concentration: 18000 nM
The estimate for compound 3 lay 1.4-fold (0.14 log units) below the measured number, and the stated range covers the measured number.
By their numbers in this assay, from the lowest: compounds 2, 1 and 3 (each within the scatter of the next).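

Among the compounds shown here, this is the first single-site step among the measured compounds. In this assay, putting dimethylamino in place of isopropylamino, on the aromatic carbon between two ring nitrogen atoms, gives a 1.4-fold higher number from compound 2 to compound 3 (0.14 log units; within the scatter) and so shows no change that this test can resolve, even though the entering group has one heavy atom fewer and no hydrogen-bond donor. The data available for this pair offer no independent measurement that would help explain this result.

On these data alone, both groups compared here are open-chain amines without a ring, so it remains open whether a morpholine ring, a carboxylic acid or a longer alkyl chain at this position would also stay within the range seen so far. A single pair also leaves open whether the same exchange would give a similarly small step on a different core, or with another group in place of the methyl group or the 1,3-benzothiazol-2-yl group.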